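A few compounds are considered here, and "the series" means these few. Any claim that something is new, unique, unknown or untested is made for them only; others in the source may bear on it.

In a functional assay on M14 cells (Homo sapiens) for inhibition, read by sulforhodamine B assay, with a stated time of 48 h (a lower number here means a stronger inhibitor of growth, a higher number a weaker inhibitor of growth), compound 1 (`COc1cccc(C(=O)NNC(=O)c2ccc3[nH]c(-c4ccc([N+](=O)[O-])o4)nc3c2)c1`) gives 7.81 ug/mL and compound 2 (`O=CNNC(=O)c1ccc2[nH]c(-c3ccc([N+](=O)[O-])o3)nc2c1`) gives 31.3 ug/mL as the higher of the two numbers, so compound 2 is the weaker growth inhibitor of the pair. Compound 3 (`COc1ccc(C(=O)NNC(=O)c2ccc3[nH]c(-c4ccc([N+](=O)[O-])o4)nc3c2)cc1OC`) is not yet measured. It differs from compound 2 by 3,4-dimethoxyphenyl in place of hydrogen on a carbonyl carbon in one place, with 3,4-dimethoxyphenyl in place of hydrogen on a carbonyl carbon. Among the compounds with values here, one measured step bears on this, a 4.0-fold higher number from compound 1 to compound 2 (0.60 log units; beyond the scatter) for hydrogen in place of 3-methoxyphenyl on a carbonyl carbon. Run in reverse, that step is a substituted phenyl replacing hydrogen, the same kind of change as the one now in view, so a modest step of similar size toward a lower number is expected in this assay for compound 3. Within the data shown here, no measured compound carries 3,4-dimethoxyphenyl, and a single step is thin support, so the range is kept wide. The estimated step is a 3.9-fold lower number from compound 2 to compound 3 (0.59 log units; beyond the scatter) and lies toward stronger growth inhibition. Compound 3 is expected at 8 ug/mL with an estimated range from 3 ug/mL to 20 ug/mL for now.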

Compound 3, concentration for 50% growth inhibition: 15.6 ug/mL
Beside the measured number, compound 3's estimate is 2.0-fold (0.29 log units) below it, and the stated range covers the measured number.
By their numbers in this assay, from the lowest: compounds 1, 3 and 2 (each within the scatter of the next, the first and the last beyond it).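

In this assay, 3,4-dimethoxyphenyl in place of hydrogen on the carbonyl carbon gives a 2.0-fold lower number from compound 2 to compound 3 (0.30 log units; within the scatter) and so, unlike 3-methoxyphenyl in the earlier pair, does not stand clear of the hydrogen compound. Methoxy in place of hydrogen on an aromatic carbon of the 3-methoxyphenyl group gives a 2.0-fold higher number from compound 1 to compound 3 (0.30 log units; within the scatter), so the extra methoxy cannot be told apart from its absence in this read-out, and a substituted phenyl at this carbonyl carbon does not by itself guarantee a step beyond the scatter; of the three compounds, only compound 1 and compound 2 are separated from each other. No measurement on hand offers an explanation for this result.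

The compounds shown leave open whether an unsubstituted phenyl, or a phenyl carrying a dimethylamino group or a carboxylic acid instead of methoxy, would separate from compound 2 at this carbonyl carbon. They also leave open whether a saturated group such as a butyl chain on the same carbonyl carbon would read like the phenyl groups or like hydrogen.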